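A Methoxypyridine in Place of a Cyanophenyl Group

A few compounds are considered here, and "the series" means these few. Any claim that something is new, unique, unknown or untested is made for them only; others in the source may bear on it.

compound 1, `CNc1nc(NCCCN(C)C)c2sc(-c3ccc(N)cc3)cc2n1`: 12.5 ug/mL
compound 2, `CNc1nc(NCCCN(C)C)c2sc(-c3ccc(S(C)(=O)=O)cc3)cc2n1`: 25 ug/mL
compound 3, `CNc1nc(NCCCN(C)C)c2sc(-c3cccc(C#N)c3)cc2n1`: 25 ug/mL

All three compounds share one core and differ only in the aromatic group attached to it. In a physicochemical assay for solubility, in phosphate buffer, at pH 6.5 (a lower number here means a less soluble compound, a higher number a more soluble compound), compound 1 gives 12.5 ug/mL, compound 2 gives 25 ug/mL, and compound 3 gives 25 ug/mL. Compound 3 sits level with compound 2, and its distance from compound 1 is a 2.0-fold higher number from compound 1 to compound 3 (0.30 log units; within the scatter); among these three numbers none stands apart from another beyond the usual scatter of this assay.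

Compound 4, `CNc1nc(NCCCN(C)C)c2sc(-c3ccc(OC)nc3)cc2n1`, is made from compound 3 by the change (6-methoxypyridin-3-yl in place of 3-cyanophenyl on an aromatic carbon). For the measured compounds named here, two measured steps bear on this kind of change, since both also swap the aromatic group at the same place: a 2.0-fold higher number from compound 1 to compound 2 (0.30 log units; within the scatter) and a 2.0-fold higher number from compound 1 to compound 3 (0.30 log units; within the scatter). Both stayed inside the scatter, even though the groups exchanged were quite different from one another. On that basis the step to compound 4 is expected to be small as well: a 1.2-fold higher number from compound 3 to compound 4 (0.08 log units; within the scatter), with no change beyond the scatter. Compound 4 is therefore estimated to give 30 ug/mL in this assay, with a likely range from 10 ug/mL to 90 ug/mL.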

Compound 4, solubility: 25 ug/mL
Compound 4: the middle estimate sits 1.2-fold (0.08 log units) above what was measured; the measured number falls inside the stated range.
By their numbers in this assay, from the lowest: compounds 1, 2, 3 and 4 (each within the scatter of the next).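

In this assay the exchange of 3-cyanophenyl for 6-methoxypyridin-3-yl, on an aromatic carbon next to the ring sulfur, gives no change at the digits printed from compound 3 to compound 4 (within the scatter) and so extends the range of groups read at this place: compounds 1, 2 and 3 all carry a six-membered aromatic ring of carbon only, whereas compound 4 carries one with a hetero atom. Read against the amino compound, the result is a 2.0-fold higher number from compound 1 to compound 4 (0.30 log units; within the scatter) and matches the earlier 2.0-fold higher number from compound 1 to compound 3 (0.30 log units; within the scatter) and a 2.0-fold higher number from compound 1 to compound 2 (0.30 log units; within the scatter), so four different aromatic groups at this place remain within the scatter of one another. No measurement is available to explain why these groups read so closely in this assay.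

Every group shown at this place is a six-membered aromatic ring, so it remains open whether a carboxylic acid on that ring, or a saturated piperidine ring in its place, would stay within the scatter. The dimethylamino chain is also the same in all four compounds, which leaves open how a morpholine at its end would read alongside these aromatic groups.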